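A few compounds are considered here, and "the series" means these few. Any claim that something is new, unique, unknown or untested is made for them only; others in the source may bear on it.

Values in a functional assay for inhibition, with Sus scrofa as the target; a higher number here means a weaker inhibitor, a lower number a stronger inhibitor:
- compound 1 `CC1(C)Oc2ccc(C#N)cc2[C@@H](Oc2ccccn2)[C@]1(C)O`: 6000 nM
- compound 2 `CC1(C)Oc2ccc(C#N)cc2[C@@H](OC2=CC(=O)CC2)[C@]1(C)O`: 20 nM

Compound 2, at 20 nM, holds the lower of the two numbers. The next structure is compound 3 `CC1(C)Oc2ccc(C#N)cc2[C@@H](Oc2ccnc(O)c2)[C@]1(C)O`, which differs from compound 2 at one place: 2-hydroxypyridin-4-yl in place of 3-oxocyclopent-1-en-1-yl on an oxygen on a saturated carbon. Within the data shown here, only one measured step bears on this change: a 300-fold lower number from compound 1 to compound 2 (2.48 log units; beyond the scatter), a large step beyond the scatter. That step replaced pyridin-2-yl with 3-oxocyclopent-1-en-1-yl. In compound 3 a six-membered aromatic ring with 1 hetero atom returns, but as 2-hydroxypyridin-4-yl, which has not been measured. A move to a higher number is therefore expected, though much smaller than a full reversal of a 300-fold lower number from compound 1 to compound 2 (2.48 log units; beyond the scatter). The expected change is a 3.5-fold higher number from compound 2 to compound 3 (0.54 log units; beyond the scatter). For compound 3 the estimated value is 70 nM, with an expected range of 15 nM to 500 nM.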

Compound 3, half-maximal inhibitory concentration: 4 nM
Beside the measured number, compound 3's estimate is 18-fold (1.24 log units) above it; the whole stated range lies above it.
By their numbers in this assay, from the lowest: compound 3; then compound 2; then compound 1.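

Working notes on the group on an oxygen on a saturated carbon: in this assay, a six-membered aromatic ring with 1 hetero atom is compatible with the lowest number of the three compounds, as 2-hydroxypyridin-4-yl in place of 3-oxocyclopent-1-en-1-yl gives a modest gain (a 5.0-fold lower number from compound 2 to compound 3 (0.70 log units; beyond the scatter)). The weak number of compound 1 therefore does not follow from having such a ring at this place, and the large step from pyridin-2-yl to 2-hydroxypyridin-4-yl (a 1500-fold lower number from compound 1 to compound 3 (3.18 log units; beyond the scatter)) shows how much depends on which aromatic group is present. No supporting data explain this difference.

From the compounds shown here alone, the step from compound 1 changes both the ring attachment and the hydroxy group at once, so their separate contributions remain open. Also open, going by these compounds, is how an amine or a methoxy group would read in place of that hydroxy group.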